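The source may report more compounds than this note shows. Statements on the series, on what has been measured and on what is new or still open speak of the compounds shown alone.

Notes on the aryloxy series. Among the compounds with values here, compound 3 `N#Cc1ccc(Nc2nc(Oc3ccccc3)c3ccccc3n2)cc1` gives 370000 nM in an ADME assay on MT4 cells (Homo sapiens) for cytotoxicity, read by MTT assay, with a stated time of 4 days (on this read-out lower numbers stand for higher toxicity in this test and higher numbers for lower toxicity in this test), and stands highest of the three numbers measured so far. Compound 1 `COc1ccccc1Oc1nc(Nc2ccc(C#N)cc2)nc2ccccc12` gives 150000 nM in the same test, and compound 2 `Cc1ccc(Oc2nc(Nc3ccc(C#N)cc3)nc3ccccc23)cc1` gives 87000 nM. The steps up to compound 3 are a 2.5-fold higher number from compound 1 to compound 3 (0.39 log units; beyond the scatter) and a 4.3-fold higher number from compound 2 to compound 3 (0.63 log units; beyond the scatter), both modest but beyond the scatter.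

Compound 4 `N#Cc1ccc(Nc2nc(Oc3ccc(F)cc3)c3ccccc3n2)cc1` differs from compound 3 by fluoro in place of hydrogen on an aromatic carbon. The measured step that bears most directly on this change is a 4.3-fold higher number from compound 2 to compound 3 (0.63 log units; beyond the scatter), which concerns a substituent on the same aromatic carbon; the change to compound 4 runs the other way, putting a substituent back onto that carbon. The step of a 2.5-fold higher number from compound 1 to compound 3 (0.39 log units; beyond the scatter) points in the same direction, since both substituted phenoxy compounds show lower numbers than the unsubstituted one. Fluoro brings only a single heavy atom where methyl brought one as well, so a step of comparable or somewhat smaller size is expected. Accordingly a modest lower number is expected for compound 4 in this assay, estimated at 200000 nM with a range from 90000 nM to 420000 nM, corresponding to an expected step of a 1.9-fold lower number from compound 3 to compound 4 (0.27 log units; within the scatter).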

Compound 4, half-maximal cytotoxic concentration: > 351000 nM
Compound 4 was reported as a limit; the forecaster's own chance of this, stated with the estimate: 25%; at least 1.7-fold (0.24 log units) between middle value and limit.
By their numbers in this assay, from the lowest: compounds 2 and 1 (each within the scatter of the next); then compound 3.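

In this assay compound 4 is reported only as a limit, so the step from compound 3 cannot be read and no order between the two can be given: the limit of > 351000 nM in this assay, at which 1 of the 4 values shown sits.

The comparison with the methyl group on the same aromatic carbon can be read: fluoro in place of methyl gives an at least 4.0-fold higher number from compound 2 to compound 4 (0.60 log units; beyond the scatter). The comparison with the 2-methoxyphenyl compound can also be read, with 4-fluorophenyl in place of 2-methoxyphenyl giving an at least 2.3-fold higher number from compound 1 to compound 4 (0.36 log units; beyond the scatter). The earlier compounds shown here left it possible that any substituent on this carbon, para to a large group, would bring the number down, but compound 4 shows that this does not hold for fluoro, and the low number of compound 2 does not carry over to this change.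

From the compounds shown here alone, whether fluoro shifts the number relative to hydrogen at all remains open, as does the actual value of compound 4 beyond its limit. Also open, going by these compounds, is how an amine or a carboxylic acid on the same carbon would read in this assay, and so whether methyl stands alone among substituents at this position.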